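The compounds below may be only part of what the source reports. "The series", "measured", "known", "first", "only" and "open" are said of these compounds alone.

Measured in a functional assay on BGC-823 cells (Homo sapiens) for inhibition, read by MTT assay, with a stated time of 72 h; on this read-out lower numbers stand for stronger inhibition and higher numbers for weaker inhibition:
Compound 1 `O=C1/C(=C\c2ccccc2)c2c(ncn2COCc2ccccc2)CCN1Cc1ccccc1`: 20400 nM
Compound 2 `O=C1/C(=C\c2ccccc2)c2c(ncn2COCc2ccccc2)CCN1Cc1ccc(Cl)cc1`: 75700 nM
Compound 3 `CC(C)(C)c1ccc(CN2CCc3ncn(COCc4ccccc4)c3/C(=C/c3ccccc3)C2=O)cc1`: 27800 nM

Compound 1 shares the stronger end of this small set with compound 3. Adding chloro raises the number beyond the scatter (a 3.7-fold higher number from compound 1 to compound 2 (0.57 log units; beyond the scatter)), while adding tert-butyl stays within it (a 1.4-fold higher number from compound 1 to compound 3 (0.13 log units; within the scatter)).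

In compound 4 `O=C1/C(=C\c2ccncc2)c2c(ncn2COCc2ccccc2)CCN1Cc1ccccc1`, pyridin-4-yl stands in place of phenyl on a double-bonded chain carbon bound to a double-bonded ring carbon (pyridin-4-yl in place of phenyl on a double-bonded chain carbon bound to a double-bonded ring carbon). Within the data shown here, no measured step touches that phenyl, so these steps and the exchange of chloro for tert-butyl (a 2.7-fold lower number from compound 2 to compound 3 (0.44 log units; beyond the scatter)) bear on it only indirectly. They show that single changes on an aromatic carbon have moved the number modestly at most, and they give no direction for this exchange. The expectation is therefore no step beyond the scatter, although a modest move either way remains possible. In this assay the expected result is a 1.2-fold higher number from compound 1 to compound 4 (0.09 log units; within the scatter) (an estimate, not a measurement). The estimate for compound 4 is 25000 nM (expected range 9000 nM to 70000 nM).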

Compound 4, half-maximal inhibitory concentration: > 100000 nM
Compound 4: only a limit was reported; the forecaster's own chance of this, stated with the estimate: 3%; middle value at least 4.0-fold (0.60 log units) from the limit.
By their numbers in this assay, from the lowest: compounds 1 and 3 (each within the scatter of the next); then compound 2. At a limit, above all of these: compound 4.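

The earlier steps shown here all changed a substituent on an aromatic carbon, and none reached the phenyl on a double-bonded chain carbon bound to a double-bonded ring carbon. Putting pyridin-4-yl there, which brings in a ring nitrogen and a hydrogen-bond acceptor, gives an at least 4.9-fold higher number from compound 1 to compound 4 (0.69 log units; beyond the scatter) in this assay, so this position is not indifferent to the exchange of a single ring atom. For compound 4, > 100000 nM is a limit and not a number, so the full size of the step stays unknown: the limit of > 100000 nM in this assay, at which 1 of the 4 values shown sits.

The compounds shown leave open how this position would respond to other groups, such as pyridin-3-yl, a thiophene ring, or a phenyl carrying an amine or a carboxylic acid. They also leave open whether the same exchange would have the same effect in compound 2 or compound 3.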